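The compounds below may be only part of what the source reports. "The series", "measured", "known", "first", "only" and "open" are said of these compounds alone.

In an ADME assay on the whole organism (Canis lupus familiaris) for metabolic stability (a higher number here means that the compound lasts longer, a lower number that the compound disappears faster), compound 1 (`O=C(N[C@H]1CN(S(=O)(=O)c2ccccc2)C[C@@H]1C(=O)N[C@H]1CCCNC1)c1cc(-c2ccccc2)on1`) gives 14 h. Compound 2 (`Cc1nc(-c2cccc(C(F)(F)F)c2)sc1C(=O)N[C@H]1CN(S(=O)(=O)c2ccccc2)C[C@@H]1C(=O)N[C@H]1CCCNC1`) gives 18.9 h. Going by the values given here, these two numbers lie within the usual scatter of each other, so compound 1 stands level with the only other compound measured. Among the compounds with values here, the two compounds differ in more than one place, which leaves no single-change step to guide the next reading.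

Compound 3 (`O=C(N[C@H]1CN(S(=O)(=O)c2ccccc2)C[C@@H]1C(=O)N[C@H]1CCCNC1)c1cc(-c2ccccc2Cl)on1`) has not yet been measured. It departs from compound 1 in a single place: chloro in place of hydrogen on an aromatic carbon. This is chloro in place of hydrogen on an aromatic carbon, turning phenyl to 2-chlorophenyl. Despite its wider structural difference from compound 1, compound 2 reaches 18.9 h, still within the scatter of its partner. On that ground, no shift beyond the scatter is expected in this assay from this smaller change, and no direction can be favoured with confidence. The estimated step, a 1.1-fold higher number from compound 1 to compound 3 (0.03 log units; within the scatter), stays within the scatter. The half-life expected for compound 3 is 15 h, with an estimated range from 8 h to 26 h.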

Compound 3, half-life: 15 h
Compound 3: the middle estimate sits on the measured number at the digits printed; low and high end bracket the measured number.
By their numbers in this assay, from the lowest: compounds 1, 3 and 2 (each within the scatter of the next).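

In this assay, going by these compounds alone, the change from phenyl to 2-chlorophenyl gives the first step that can be read at a single place: a 1.1-fold higher number from compound 1 to compound 3 (0.03 log units; within the scatter). Compound 1 and compound 2 differ in more than one place, so they could not speak for any one position, whereas this pair shows that chloro in place of hydrogen, on an aromatic carbon of a six-membered aromatic ring of carbon only and ortho to a large group, leaves the half-life level within the scatter. No measurement at hand offers an explanation for this result.

What the compounds shown leave open is whether another group at this same place, such as a fluoro, a methoxy or an amine, would also leave the half-life level, or whether a step beyond the scatter can be reached here at all. Within the data shown here, they also leave open whether chloro would read the same on another carbon of that ring, or on the phenyl ring of the sulfonyl group, since this single step speaks only for the one position and the one pair.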